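This account rests on a few compounds, and the source may have more. Where it says the series, first, only, none or still open, it means among the compounds named here.

compound 1 `Cc1nnsc1CO/N=C/c1c(C)nn(C)c1Oc1cccc(F)c1`: > 50000 nM
compound 2 `Cc1nnsc1CO/N=C/c1c(C)nn(C)c1Oc1ccc(Br)cc1`: 15200 nM

Two measurements exist in a functional assay on SGC-7901 cells (Homo sapiens) for inhibition, read by MTT assay, with a stated time of 48 h; a higher number here means a weaker inhibitor, a lower number a stronger inhibitor. For compound 1 the value is only a limit of the assay, > 50000 nM. Within the data shown here, compound 2 is the one compound with a number, 15200 nM, so it stands alone with nothing else to rank it against. Among the measured compounds shown here, the single step, an at least 3.2-fold lower number from compound 1 to compound 2 (0.51 log units; beyond the scatter), runs beyond the scatter, but it rests on the limit of > 50000 nM in this assay, at which 1 of the 2 values shown sits, and so gives a floor rather than a size. Compound 3 `Cc1nnsc1CO/N=C/c1c(C)nn(C)c1Oc1ccc(I)cc1` differs from compound 2 by iodo in place of bromo on an aromatic carbon. For the measured compounds named here, no measured step exchanges one halogen for another in the same place; the step from compound 1 to compound 2 changes both the halogen and where it sits and so bears on this only loosely. For compound 3 the expected step of a 1.3-fold lower number from compound 2 to compound 3 (0.10 log units; within the scatter) is none beyond the scatter. Compound 3 is estimated at 12000 nM in this assay, with a range from 5000 nM to 35000 nM.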

Compound 3, half-maximal inhibitory concentration: > 50000 nM
Compound 3: only a limit was reported; the forecaster's own chance of this, stated with the estimate: 10%; middle value at least 4.1-fold (0.61 log units) from the limit.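

In this assay, among these compounds, iodo in place of bromo, on an aromatic carbon para to a large group, gives an at least 3.2-fold higher number from compound 2 to compound 3 (0.51 log units; beyond the scatter) and so is the first direct halogen exchange at this position, one that does not leave the read-out unchanged. The value for compound 3 is a limit, which makes this step a floor rather than a size, and the one measured number in the series remains that of compound 2, with the step between compound 1 and compound 3 unreadable as both values are limits: the limit of > 50000 nM in this assay, at which 2 of the 3 values shown sit.

The compounds shown leave open whether the number for compound 2 is specific to bromo or would also hold for chloro, methoxy or an amine on the same carbon. With a single number in hand, no trend across the halogens can be stated.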